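A Hydroxy Group Added to Compound 3

A few compounds are considered here, and "the series" means these few. Any claim that something is new, unique, unknown or untested is made for them only; others in the source may bear on it.

Of the compounds shown here, three have been tested in a functional assay on A549 cells (Homo sapiens) for inhibition, with a stated time of 48 h; on this read-out higher numbers stand for weaker inhibition and lower numbers for stronger inhibition. Compound 1, `COc1ccc2c(=O)cc(/C=C/[S+](C)[O-])oc2c1O`, returns only a limit of the assay, > 10000 nM. Compound 2, `COc1cc2oc(/C=C/[S+](C)[O-])cc(=O)c2cc1O`, likewise returns only a limit, > 10000 nM. Within the data shown here, compound 3, `C[S+]([O-])/C=C/c1cc(=O)c2ccccc2o1`, is the one compound with an actual number; in this assay compound 3 gives 10000 nM. Compound 3 therefore stands as the only number shown, while the two other values sit at the limit of > 10000 nM in this assay, at which 2 of the 3 values shown sit.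

Compound 4, `C[S+]([O-])/C=C/c1cc(=O)c2cc(O)ccc2o1`, has not yet been measured. It differs from compound 3 in a single change: hydroxy in place of hydrogen on an aromatic carbon. Among the measured compounds shown here, no pair of measured compounds differs in only one place, so no measured step guides this change directly. Compound 1 carries a hydroxy group and sits at the limit. Compound 2 also carries a hydroxy group and sits at the limit. Compound 3, without one, already gives a weak number. The expected step is a 1.2-fold higher number from compound 3 to compound 4 (0.08 log units; within the scatter), that is, nothing beyond the scatter or a drift toward weaker inhibition. Compound 4 is expected to give about 12000 nM in this assay, within a range from 5000 nM to 30000 nM, with a fair chance that only a limit is reported.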

Compound 4, half-maximal inhibitory concentration: > 10000 nM
Compound 4: no number, only a limit; the forecaster's own chance of this, stated with the estimate: 60%; the middle value is on the limit's open side.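

In this assay, among these compounds, this is the first change in one place that can be read at all, and hydroxy in place of hydrogen on an aromatic carbon gives a number no lower from compound 3 to compound 4 (the limit leaves the size open). At this position, meta to a fused ring and para to a fused ring, hydroxy therefore brings no stronger inhibition than the hydrogen of compound 3. Compound 4 returns only a limit and joins the other compounds there: the limit of > 10000 nM in this assay, at which 3 of the 4 values shown sit.

Going by these compounds, the step between compound 2 and compound 4 cannot be read, since both values are limits, and the size of the loss, if any, from compound 3 to compound 4 stays unknown as well. On these data alone, whether an amine or a carboxylic acid at this position would give a stronger inhibition than hydroxy also remains open.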